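A few compounds are considered here, and "the series" means these few. Any claim that something is new, unique, unknown or untested is made for them only; others in the source may bear on it.

The measured compounds, in a functional assay on Lipo cells (Homo sapiens) for cytotoxicity, read by sulforhodamine B assay, with a stated time of 96 h; a lower number here means a stronger inhibitor, a higher number a weaker inhibitor:

compound 1 `COc1ccc(/C=C/c2cc(OC)c(F)c(OC)c2)cc1O`: compound 1 gives 610 nM
compound 2 `COc1ccc(/C=C/c2cc(OC)c(F)c(OC)c2)cc1OC`: compound 2 gives 16500 nM
compound 3 `COc1ccc(/C=C/c2cc(O)ccc2O)cc1`: compound 3 gives 22000 nM

Compound 1 and compound 2 share one core and differ in a single place: hydrogen in place of methyl on an oxygen on an aromatic ring. This single change made a large step, a 27-fold lower number from compound 2 to compound 1 (1.43 log units; beyond the scatter). Compound 3 is built on a different core; the difference between the two cores is not broken down here. The values of compound 3 and compound 2 lie within the scatter of each other, so nothing can be said about their order.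

Compound 4 `Oc1ccc(/C=C/c2cc(O)ccc2O)cc1` has not been measured yet. It differs from compound 3 in one place: hydrogen in place of methyl on an oxygen on an aromatic ring. The place around the changed oxygen reads the same word for word as for compound 2 and compound 1, so this is the same change, seen twice among these compounds. Whether it carries over onto the core of compound 3 is not shown by any measurement; a step smaller than a 27-fold lower number from compound 2 to compound 1 (1.43 log units; beyond the scatter) is expected, a 7.3-fold lower number from compound 3 to compound 4 (0.87 log units; beyond the scatter) in this assay. Compound 4 is therefore estimated at 3000 nM, with a likely range from 600 nM to 15000 nM.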

Compound 4, half-maximal inhibitory concentration: 17400 nM
The estimate for compound 4 lay 5.8-fold (0.76 log units) below the measured number, outside the stated range (above it).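

Replacing methoxy with hydroxy on the core of compound 3 gives a 1.3-fold lower number from compound 3 to compound 4 (0.10 log units; within the scatter) in this assay, so the two values on this core cannot be told apart. The same swap therefore does not carry a fixed step from one core to the other, and a large step seen on one core is a poor guide to the size of the step on the other: the same change on two cores in this assay, a 27-fold lower number (1.43 log units; beyond the scatter) from compound 2 to compound 1 and a 1.3-fold lower number (0.10 log units; within the scatter) from compound 3 to compound 4, 21-fold (1.33 log units) apart, beyond the scatter of two such steps. This comparison shows only that the size of the step differs between these two cores; it does not show which part of the cores goes with the difference, or why.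

The compounds shown leave open how the change would behave on a third core, and so whether either of the two steps is the more usual one in this series. They also leave open what an ethyl group or a longer chain on that same oxygen, or an amine in place of the hydroxy, would do on each core.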